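Working notes: the amide change from compound 3 to compound 4

The compounds below may be only part of what the source reports. "The series", "measured", "known", "first", "only" and "open" are said of these compounds alone.

Measured so far in an assay on HeLa cells for inhibition of Kinesin-like protein KIF15 (Homo sapiens), read by microscopy, with stated times of 2 s and 20 s, tested at 750 nM; a lower number here means less inhibition, a higher number more inhibition at the concentration tested (going by the name of the read-out):
- compound 1, `Cc1cc(/C=C2\C(=O)Nc3ccc(C(=O)c4ccco4)cc32)cc(C)c1O`, gives 9%
- compound 2, `O=C1Nc2ccc(C(=O)c3ccco3)cc2/C1=C/c1ccnc(Cl)c1`, gives 15.8%
- compound 3, `O=C1Nc2ccc(C(=O)NCc3ccccc3)cc2/C1=C/c1cc(Cl)c(O)c(Cl)c1`, gives -24%

Compound 3 stands lowest of the three numbers in this assay. Its nearest neighbour is compound 1, higher by a margin beyond the scatter, and compound 2 lies further off, also beyond the scatter. Within the data shown here, the one step recorded so far, a number 6.8 percentage points higher from compound 1 to compound 2 (within the scatter), changes the group on the double-bonded chain carbon and leaves the amide side untouched; it is within the scatter.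

Compound 4, `CN(C)C(=O)c1ccc2c(c1)/C(=C/c1cc(Cl)c(O)c(Cl)c1)C(=O)N2`, differs from compound 3 as follows: dimethylamino in place of benzylamino on a carbonyl carbon. Among the measured compounds shown here, no measured step touches the carbonyl carbon bound to the aromatic carbon, so there is no precedent for this change in this assay. For the measured compounds named here, the only recorded step is small and elsewhere on the shared core, so no step beyond the scatter is expected here. Compound 4 is therefore estimated at -10%, with a range from -35% to 15%, which means an expected step of a number 14 percentage points higher from compound 3 to compound 4 (beyond the scatter).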

Compound 4, a percentage reported as inhibition, at one concentration (the size of the read-out at that concentration, not a potency): 15.3%
For compound 4 the middle estimate is 25.3 percentage points below the measured one; the whole stated range lies below it.
By their numbers in this assay, from the lowest: compound 3; then compounds 1, 4 and 2 (each within the scatter of the next).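

On the carbonyl carbon whose other neighbour is an aromatic carbon, dimethylamino in place of benzylamino gives, in this assay, a number 39.3 percentage points higher from compound 3 to compound 4 (beyond the scatter). Among these compounds, this is the only step so far that is beyond the scatter, whereas a number 6.8 percentage points higher from compound 1 to compound 2 (within the scatter), on the double-bonded chain carbon, is not, so the group on this carbonyl carbon can move the read-out by a clear margin. The change removes the six-membered aromatic ring and the hydrogen-bond donor of benzylamino together, and nothing available bears on the cause of the step.

This single pair leaves open whether the ring or the amide hydrogen matters: methylamino would keep the donor without the ring, and N-methylbenzylamino would keep the ring without the donor. A cyclic amine such as morpholine on the same carbonyl carbon would show how far the step extends beyond dimethylamino.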